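A few compounds are considered here, and "the series" means these few. Any claim that something is new, unique, unknown or untested is made for them only; others in the source may bear on it.

Measured compounds:
- Compound 1 `COc1cc(Sc2c[nH]c3ccc(Cl)cc23)cc(OC)c1OC`: in a functional assay on MCF7 cells (Homo sapiens) for inhibition, with a stated time of 48 h (on this read-out higher numbers stand for weaker inhibition and lower numbers for stronger inhibition), compound 1 gives 77 nM.
- Compound 2 `COc1cc(Sc2c(C)[nH]c3ccc(Cl)cc23)cc(OC)c1OC`: compound 2 gives 82 nM.
- Compound 3 `COc1cc(Sc2c[nH]c3ccc([N+](=O)[O-])cc23)cc(OC)c1OC`: compound 3 gives 560 nM.

Compound 3 has the highest number of the three, beyond the scatter from both compound 1 and compound 2. The step of a 7.3-fold higher number from compound 1 to compound 3 (0.86 log units; beyond the scatter) is the only one that touches the position now in question; the step of a 1.1-fold higher number from compound 1 to compound 2 (0.03 log units; within the scatter) sits elsewhere on the core and lies within the scatter.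

Compound 4 `COc1cc(Sc2c[nH]c3ccc(O)cc23)cc(OC)c1OC` differs from compound 3 by hydroxy in place of nitro on an aromatic carbon. Among the compounds with values here, no measured step removes a nitro or brings in a hydroxy, so the direction rests only on a 7.3-fold higher number from compound 1 to compound 3 (0.86 log units; beyond the scatter), which shows that a change at this carbon can move the number well beyond the scatter. Taking the nitro out is expected to bring the number back down by a modest step, a 2.8-fold lower number from compound 3 to compound 4 (0.45 log units; beyond the scatter), though the size is uncertain. Compound 4 is estimated at 200 nM, with a range from 60 nM to 700 nM.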

Compound 4, half-maximal inhibitory concentration: 190 nM
Compound 4: the middle estimate sits 1.1-fold (0.02 log units) above what was measured; low and high end bracket the measured number.
By their numbers in this assay, from the lowest: compounds 1 and 2 (each within the scatter of the next); then compound 4; then compound 3.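

In this assay, hydroxy in place of nitro on this aromatic carbon gives a 2.9-fold lower number from compound 3 to compound 4 (0.47 log units; beyond the scatter) and so recovers part of the loss seen with nitro. Hydroxy in place of chloro still gives a 2.5-fold higher number from compound 1 to compound 4 (0.39 log units; beyond the scatter) and so does not match chloro: at this carbon the three groups separate beyond the scatter, with chloro lowest, then hydroxy, then nitro. No available evidence bears on the reason for this order. Where an amine, a methoxy or a bromo would fall in this order remains open. Also open, going by these compounds, is whether the order holds with the methyl of compound 2 on the core.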